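Chloropropylurea to acrylamide on the methoxy-pentyl aniline core

A few compounds are considered here, and "the series" means these few. Any claim that something is new, unique, unknown or untested is made for them only; others in the source may bear on it.

Measured so far:
compound 1 `CCCCC(O)c1cccc(NC(=O)NCCCCl)c1`: 19000 nM
compound 2 `CCCCC(OC)c1cccc(NC(=O)NCCCCl)c1`: 56000 nM

In a functional assay on HT-29 cells (Homo sapiens) for antiproliferative activity, with a stated time of 48 h (a higher number here means a weaker inhibitor, a lower number a stronger inhibitor), compound 1 gives 19000 nM. Compound 2 carries a methyl in place of hydrogen on the oxygen at the saturated carbon; in this assay compound 2 gives 56000 nM, the higher of the two numbers, and the step of a 2.9-fold higher number from compound 1 to compound 2 (0.47 log units; beyond the scatter) lies beyond the scatter. Compound 2 therefore stands at the weak end of what has been measured.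

Compound 3 `C=CC(=O)Nc1cccc(C(CCCC)OC)c1` keeps the methoxy-bearing side chain of compound 2 and changes the other side: vinyl in place of (3-chloropropyl)amino on a carbonyl carbon. Among the measured compounds shown here, neither measured step touches this position; the only step in hand, from compound 1 to compound 2, concerns the oxygen on the saturated carbon and says nothing about what the carbonyl carbon tolerates. For the measured compounds named here, no measured step bears on the change, so no direction can be argued from the data, and the expected step is set at none beyond the scatter with a wide range. On that basis compound 3 is expected to give 35000 nM in this assay, within 6000 nM to 200000 nM, an expected step of a 1.6-fold lower number from compound 2 to compound 3 (0.20 log units; within the scatter).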

Compound 3, half-maximal inhibitory concentration: 40000 nM
Estimate against measurement, compound 3: 1.1-fold (0.06 log units) below; low and high end bracket the measured number.
By their numbers in this assay, from the lowest: compound 1; then compounds 3 and 2 (each within the scatter of the next).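

Among the compounds shown here, compound 2 and compound 3 are the first pair to differ at the carbonyl carbon. In this assay, vinyl in place of (3-chloropropyl)amino gives a 1.4-fold lower number from compound 2 to compound 3 (0.15 log units; within the scatter), so the two groups cannot be told apart here, even though the group that leaves has more heavy atoms, including the chlorine, and carries a hydrogen-bond donor. The earlier step at the oxygen on the saturated carbon, a 2.9-fold higher number from compound 1 to compound 2 (0.47 log units; beyond the scatter), lies beyond the scatter, so in this small set the change at the carbonyl carbon is the one with no readable effect on the number, and no available data bear on why this is so.

Open is whether this holds with the free hydroxyl of compound 1 on the saturated carbon, since vinyl is shown only with the methoxy-bearing side chain. Also open, from the compounds shown here alone, is how the carbonyl carbon responds to an ethyl group, the saturated counterpart of vinyl, or to a longer chain or a dimethylamino group, any of which could show whether this position responds at all.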